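A few compounds are considered here, and "the series" means these few. Any claim that something is new, unique, unknown or untested is made for them only; others in the source may bear on it.

Measured in an ADME assay on HaCaT cells (Homo sapiens) for inhibition, read by sulforhodamine B assay, with a stated time of 48 h; a lower number here means a stronger inhibitor of growth, a higher number a weaker inhibitor of growth:
- compound 1 `CCOC(=O)c1nn(-c2ccccc2)c(-c2ccc(F)cc2)c1CNC(C)(C)C`: 74500 nM; 32900 nM (2 entries)
- compound 2 `CCOC(=O)c1nn(-c2ccccc2)c(-c2ccccc2)c1CNC(C)(C)C`: 77000 nM; 13300 nM (2 entries)
- compound 3 `CC(C)(C)NCc1c(C(=O)O)nn(-c2ccccc2)c1-c1ccc(F)cc1`: > 680000 nM (a limit, not a number)

Compound 3 has no single number in this assay. Its reading of > 680000 nM is a limit, and its two further entries also give no single number.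

Compound 4 `CC(C)(C)NCc1c(C(=O)O)nn(-c2ccccc2)c1-c1ccc([N+](=O)[O-])cc1` differs from compound 3 by nitro in place of fluoro on an aromatic carbon, para to a large group, a change from 4-fluorophenyl to 4-nitrophenyl: nitro in place of fluoro on an aromatic carbon.

Within the data shown here, no measured pair shows a change at this place, so the data give no direction for it. In this assay, no step beyond the scatter is expected. This expectation rests on compound 3 alone, with its reading of > 680000 nM, which is a limit. A further limit is the likeliest outcome for compound 4. Should a number be reported, the expected change is an at least 1.1-fold lower number from compound 3 to compound 4 (0.05 log units; that floor lies within the scatter). For compound 4 the estimated value is 600000 nM, with an expected range of 200000 nM to 1000000 nM.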

Compound 4, concentration for 50% growth inhibition: > 634000 nM
Compound 4 was reported as a limit (the forecaster's own chance of this, stated with the estimate: 75%); middle value at least 1.0-fold (0.02 log units) away from the limit.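

Among these compounds, compound 3 and compound 4 each stand only as limits in this assay, and no step between them can be read. The compounds shown leave open whether 4-nitrophenyl in place of 4-fluorophenyl shifts growth inhibition in either direction.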